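A few compounds are considered here, and "the series" means these few. Any claim that something is new, unique, unknown or untested is made for them only; others in the source may bear on it.

Compound 1 `CN1C(=O)C(O)(Cc2nnn[nH]2)c2cc(F)ccc21`: > 100000 nM (a limit)
Compound 2 `CN1C(=O)C(O)(Cc2nnn[nH]2)c2cc(Cl)ccc21`: > 100000 nM (a limit)
Compound 3 `CCN1C(=O)C(O)(Cc2nnn[nH]2)c2cc(Cl)ccc21`: 49500 nM

All three compounds were tested in a functional assay on PA-1 cells (Homo sapiens) for antiproliferative activity, read by MTT assay, with a stated time of 48 h; a lower number here means a stronger inhibitor, a higher number a weaker inhibitor. Compound 2 gives no actual number, only the limit > 100000 nM. Compound 4 `Cc1ccc2c(c1)C(O)(Cc1nnn[nH]1)C(=O)N2C` differs from it in one place, with methyl in place of chloro on an aromatic carbon. The measured step closest to this change, also on an aromatic carbon, is a step that the two limits leave unreadable from compound 1 to compound 2. The other measured step, an at least 2.0-fold lower number from compound 2 to compound 3 (0.30 log units; that floor lies within the scatter), concerns the chain on the amide-type nitrogen, so it bears on this change only weakly. Neither gives a readable size for a swap on the aromatic carbon, so no step beyond the scatter is expected in this assay, and no direction can be favoured. The expected change is a number no higher from compound 2 to compound 4 (the limit leaves the size open). Compound 4 is estimated at 100000 nM, with an expected range of 40000 nM to 200000 nM.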

Compound 4, half-maximal inhibitory concentration: > 100000 nM
Compound 4 ended at the assay's limit; the forecaster's own chance of this, stated with the estimate: 65%; the middle value lies on the limit itself.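

Compound 4, like compound 1 and compound 2, gives only a limit and not an actual number, so the steps among these three cannot be read: the limit of > 100000 nM in this assay, at which 3 of the 4 values shown sit.

The compounds shown leave open whether methyl, chloro or fluoro on this aromatic carbon changes the number at all.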